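This account rests on a few compounds, and the source may have more. Where it says the series, first, only, none or still open, it means among the compounds named here.

Measured in a functional assay on A549 cells (Homo sapiens) for inhibition, read by MTT assay, with a stated time of 72 h; on this read-out lower numbers stand for stronger inhibition and higher numbers for weaker inhibition:
- compound 1 `Nc1nc2cc(-c3nn(CCCC(=O)NO)c4ncnc(N)c34)ccc2o1` gives > 100000 nM (a limit)
- compound 2 `Nc1ncnc2c1c(-c1cnc3[nH]ccc3c1)nn2CCCCCC(=O)NO` gives > 150000 nM (a limit)

Compound 1 stands at the limit of > 100000 nM in this assay, at which 1 of the 2 values shown sits, and so has no number of its own. Compound 2 also stands at a limit, at the limit of > 150000 nM in this assay, at which 1 of the 2 values shown sits. Among the measured compounds shown here, neither compound gives a number in this assay, so the two cannot be ranked and no measured step is available to scale the next change.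

Compound 3 `Nc1nc2cc(-c3nn(CCCCCCCCCC(=O)NO)c4ncnc(N)c34)ccc2o1` carries 6-(hydroxycarbamoyl)hexyl in place of hydroxycarbamoyl on a saturated chain carbon, three bonds along the chain from an aromatic nitrogen. The rest of the core of compound 1 is kept.

With compound 1 at > 100000 nM as a limit, any number obtained for compound 3 would most likely fall on the lower side, meaning stronger inhibition. For the measured compounds named here, a large step in that direction is expected in this assay, but this is a tentative call with no measured step behind it, and another limit remains possible. The estimated change is an at least 20-fold lower number from compound 1 to compound 3 (1.30 log units; beyond the scatter) in this direction. The expected value for compound 3 is 5000 nM, with an estimated range of 500 nM to 50000 nM on this read-out.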

Compound 3, half-maximal inhibitory concentration: > 50000 nM
Compound 3 gave a limit, no number; the forecaster's own chance of this, stated with the estimate: 25%; middle value at least 10-fold (1.00 log units) away from the limit.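

In this assay compound 3 gives > 50000 nM, a limit and not a number. Compound 1 gives > 100000 nM, also a limit. The step between compound 1 and compound 3 therefore cannot be read. Left open is whether 6-(hydroxycarbamoyl)hexyl in place of hydroxycarbamoyl changes inhibition at all in this assay.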